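Sulfonate series: iodo for isopropyl on the urea side

The compounds below may be only part of what the source reports. "The series", "measured", "known", "first", "only" and "open" are said of these compounds alone.

Two aryl sulfonates have been measured so far. Compound 1 `CCCC(=O)Nc1ccc(S(=O)(=O)Oc2ccccc2I)cc1` carries a butanamide on one ring and an iodo group on the other; in a functional assay on MCF7 cells (Homo sapiens) for antiproliferative activity, read by sulforhodamine B assay, with a stated time of 48 h (on this read-out higher numbers stand for weaker inhibition and lower numbers for stronger inhibition), compound 1 gives 9700 nM. Compound 2 `CCCCCNC(=O)Nc1ccc(S(=O)(=O)Oc2ccccc2C(C)C)cc1` pairs a pentylurea with an isopropyl group; in this assay compound 2 gives 4000 nM, the lower of the two numbers, and the gap to compound 1 is beyond the scatter. Among the compounds with values here, the two compounds differ in two places at once, so the values show only that compound 2 is the stronger inhibitor here, not which change accounts for it.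

Compound 3 `CCCCCNC(=O)Nc1ccc(S(=O)(=O)Oc2ccccc2I)cc1` keeps the pentylurea of compound 2 and makes a single change: iodo in place of isopropyl on an aromatic carbon. Within the data shown here, no measured pair isolates this change. Compound 1 shows that an iodo group is compatible with activity in this range, while the urea side of compound 2 is retained unchanged. The step from compound 2 to compound 3 in this assay is therefore expected to be small, a 1.3-fold higher number from compound 2 to compound 3 (0.10 log units; within the scatter), in either direction within the scatter. For compound 3 in this assay the estimate is 5000 nM, with a range from 2000 nM to 13000 nM.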

Compound 3, half-maximal inhibitory concentration: 5400 nM
The estimate for compound 3 lay 1.1-fold (0.03 log units) below the measured number, within the range that was stated.
By their numbers in this assay, from the lowest: compounds 2, 3 and 1 (each within the scatter of the next, the first and the last beyond it).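

In this assay, iodo in place of isopropyl on an aromatic carbon gives a 1.4-fold higher number from compound 2 to compound 3 (0.13 log units; within the scatter), so with the pentylurea held fixed, this change, ortho to a large group, does not separate the two compounds, even though three carbons leave and one iodine enters. With the iodo group held fixed, pentylamino in place of propyl on a carbonyl carbon gives a 1.8-fold lower number from compound 1 to compound 3 (0.25 log units; within the scatter), so the wider gap between the two earlier compounds now divides into two single steps, neither of them beyond the scatter on its own. Nothing available explains either step.

As far as these compounds go, whether this aromatic carbon also tolerates a chloro, a methoxy or a carboxylic acid, or only groups like the two seen here, stays open. Also open, from the compounds shown here alone, are the effect of a longer chain or a terminal amine in place of the pentyl group on the urea, and whether the two single steps would combine in the same way on other members.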